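The compounds below may be only part of what the source reports. "The series", "measured", "known", "first", "only" and "open" are said of these compounds alone.

Compound 1 `O=C(O)CCn1c(=O)oc2cc(OCC3CCC3)c(Cl)cc21`: 1260 nM
Compound 2 `C[C@@H](Oc1cc2oc(=O)n(CCC(=O)O)c2cc1Cl)c1ncccn1`: 3160 nM

In an assay on HEK293 cells for inhibition of kynurenine 3-monooxygenase (Homo sapiens), read by LC-MS, with a stated time of 20 h (on this read-out higher numbers stand for weaker inhibition and lower numbers for stronger inhibition), compound 2 gives 3160 nM, the highest of the two numbers shown; its nearest neighbour is compound 1, whose number is lower by the step of a 2.5-fold higher number from compound 1 to compound 2 (0.40 log units; beyond the scatter). Compound 3 `C[C@@H](Oc1cc2oc(=O)n(CCC(=O)O)c2cc1Cl)c1ncco1` differs from compound 2 in one place: 1,3-oxazol-2-yl in place of pyrimidin-2-yl on a saturated chain carbon bound to an oxygen on an aromatic ring and a saturated chain carbon. Among the compounds with values here, only one measured step exists, a 2.5-fold higher number from compound 1 to compound 2 (0.40 log units; beyond the scatter), and it bears on this change only loosely, since it exchanged the whole group on the oxygen on the aromatic ring rather than one aromatic ring for another on the saturated chain carbon. Within the data shown here, no measured pair shows what swapping one ring with two hetero atoms for another does here, so the account expects no step beyond the scatter in this assay, with the number for compound 3 estimated to stay near that of compound 2. The estimated step is a 1.1-fold lower number from compound 2 to compound 3 (0.02 log units; within the scatter), and compound 3 is expected to give about 3000 nM, within 1200 nM to 8000 nM.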

Compound 3, half-maximal inhibitory concentration in the kynurenine 3-monooxygenase assay: 7940 nM
Compound 3: middle estimate off by 2.6-fold (0.42 log units), on the low side; measured number inside the range.
By their numbers in the kynurenine 3-monooxygenase assay, from the lowest: compound 1; then compound 2; then compound 3.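

In the kynurenine 3-monooxygenase assay, the ring on the saturated chain carbon bound to an oxygen on an aromatic ring and a saturated chain carbon matters even when the hydrogen-bond donor and acceptor counts stay the same: 1,3-oxazol-2-yl in place of pyrimidin-2-yl gives a 2.5-fold higher number from compound 2 to compound 3 (0.40 log units; beyond the scatter), and the whole group exchanged on the oxygen on an aromatic ring gives a 6.3-fold higher number from compound 1 to compound 3 (0.80 log units; beyond the scatter). In a physicochemical assay for permeability, using PAMPA (on this read-out higher numbers stand for higher permeability and lower numbers for lower permeability), compound 2 gives < 3 nm/s, which is a limit of the assay and not a number. In the physicochemical assay, compound 3 gives < 3 nm/s, which is also a limit.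

Going by these compounds, the step between these two limits cannot be read, since both compounds sit at the same limit: the limit of < 3 nm/s in the physicochemical assay, at which 2 of the 2 values shown sit. Whether a phenyl ring, or an amine on the pyrimidin-2-yl ring, at this saturated chain carbon would bring the number back towards that of compound 1 stays open.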